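Series notes: aminochloropyridinyl ether in place of propanoylamino pyridinyl

This account rests on a few compounds, and the source may have more. Where it says the series, first, only, none or still open, it means among the compounds named here.

Compound 1 `CCC(=O)Nc1cc(Oc2ccc(Nc3nccc4[nH]cc(-c5ccc(F)cc5)c(=O)c34)cc2F)ccn1` gives the highest of the two numbers in a functional assay on MKN-45 cells (Homo sapiens) for antiproliferative activity, read by MTT assay, with a stated time of 72 h, tested at 10 uM (on this read-out lower numbers stand for less inhibition and higher numbers for more inhibition at the one concentration tested (going by the name of the read-out)), at 92.1%. Going by the values given here, its only measured neighbour is compound 2 `CC(C)(O)C(=O)Nc1cc(Oc2ccc(Nc3nccc4[nH]cc(-c5ccc(F)cc5)c(=O)c34)cc2F)ccn1`, which in this assay gives 57.8%; the single step in hand, a number 34.3 percentage points lower from compound 1 to compound 2 (beyond the scatter), shows that a change on the carbonyl carbon alone can cost much. Compound 3 `Nc1nccc(Oc2ccc(Nc3nccc4[nH]cc(-c5ccc(F)cc5)c(=O)c34)cc2F)c1Cl` differs from compound 1 by 2-amino-3-chloropyridin-4-yl in place of 2-(propanoylamino)pyridin-4-yl on an oxygen on an aromatic ring, that is, the 2-(propanoylamino)pyridin-4-yl group leaves entirely rather than only the ethyl on its carbonyl carbon. The step from compound 1 to compound 2 bears on this only indirectly: the amide altered there is absent in compound 3. Among the compounds with values here, with one step of that size as the only guide, a lowering beyond the scatter is expected, a number 22.1 percentage points lower from compound 1 to compound 3 (beyond the scatter), though smaller than the measured one. Compound 3 is therefore estimated at 70%, between 40% and 92% in this assay.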

Compound 3, a percentage reported as inhibition, at one concentration (the size of the read-out at that concentration, not a potency): 85.7%
Compound 3: middle estimate off by 15.7 percentage points, on the low side; the range from low to high includes it.
By their numbers in this assay, from the lowest: compound 2; then compounds 3 and 1 (each within the scatter of the next).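

In this assay, 2-amino-3-chloropyridin-4-yl in place of 2-(propanoylamino)pyridin-4-yl on an oxygen on an aromatic ring gives a number 6.4 percentage points lower from compound 1 to compound 3 (within the scatter) and so leaves the read-out unresolved between the two groups. At this one concentration, the amide of compound 1 is therefore not needed at this place, and the large step of a number 34.3 percentage points lower from compound 1 to compound 2 (beyond the scatter) does not carry over to a change that removes that amide altogether. Nothing measured here gives a reason for this result.

Open, from the compounds shown here alone, are the separate shares of the amine and the chlorine in the entering group, for instance whether 2-aminopyridin-4-yl, without the chlorine, would hold the read-out. Also open, going by these compounds, is how a longer chain such as butanoyl on the carbonyl carbon would read, and whether compound 1 and compound 3 would stay level in potency across a range of concentrations.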